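Swapping the Aryl Amine Substituent on a Shared Core

The compounds below may be only part of what the source reports. "The series", "measured", "known", "first", "only" and "open" are said of these compounds alone.

Going by the values given here, compound 2 `FC(F)(F)c1ccc(CSc2nc(Nc3cccc(Cl)c3)c3ccccc3n2)cc1` gives 14600 nM in a functional assay on MGC-803 cells (Homo sapiens) for cytotoxicity, read by MTT assay, with a stated time of 72 h (a lower number here means a stronger inhibitor, a higher number a weaker inhibitor), the only number among the values at hand. Compound 1 `CCOc1ccccc1Nc1nc(SCc2ccc(C(F)(F)F)cc2)nc2ccccc12` returns only a limit in this assay, > 50000 nM. The change between them, 3-chlorophenyl in place of 2-ethoxyphenyl on the nitrogen, gave an at least 3.4-fold lower number from compound 1 to compound 2 (0.53 log units; beyond the scatter), read against (the limit of > 50000 nM in this assay, at which 1 of the 2 values shown sits). Compound 3 `O=[N+]([O-])c1ccc(Nc2nc(SCc3ccc(C(F)(F)F)cc3)nc3ccccc23)cc1` differs from compound 2 by 4-nitrophenyl in place of 3-chlorophenyl on a nitrogen on an aromatic ring. Among the compounds with values here, only that single step on the same nitrogen bears on it, and it ran from a limit toward a lower number, so compound 3 is expected to stay near that value, with a 1.2-fold lower number from compound 2 to compound 3 (0.09 log units; within the scatter). For compound 3 the estimate in this assay is 12000 nM, spanning 4000 nM to 40000 nM.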

Compound 3, half-maximal inhibitory concentration: 8170 nM
Compound 3: the middle estimate sits 1.5-fold (0.17 log units) above what was measured; the measured number falls inside the stated range.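

In this assay, the new step on this nitrogen is a 1.8-fold lower number from compound 2 to compound 3 (0.25 log units; within the scatter), so 4-nitrophenyl and 3-chlorophenyl cannot be told apart here. A second replacement of 2-ethoxyphenyl now points the same way as the first, giving an at least 6.1-fold lower number from compound 1 to compound 3 (0.78 log units; beyond the scatter). The size of that step is only a bound, as the value for compound 1 is a limit of the assay: the limit of > 50000 nM in this assay, at which 1 of the 3 values shown sits.

The compounds shown leave open how a phenyl ring carrying an amine or a carboxylic acid in place of the nitro group would read on this nitrogen. They also leave open how an unsubstituted phenyl would compare.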